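Working notes: 2,4-dimethoxyphenyl in place of 3-hydroxyphenyl

The source may hold more compounds than are shown below. What is called first, only, known or untested is meant among the compounds shown, and "the series" means these compounds.

Within the data shown here, in a functional assay on MCF7 cells (Homo sapiens) for inhibition, read by MTT assay, with a stated time of 48 h (a higher number here means a weaker inhibitor, a lower number a stronger inhibitor), compound 2 `Oc1cccc(C(c2c[nH]c3ccc(Br)cc23)c2c[nH]c3ccc(Br)cc23)c1` gives 2800 nM, the lowest of the three numbers so far. Compound 1 `c1ccc(C(c2c[nH]c3ccccc23)c2c[nH]c3ccccc23)cc1` gives 22200 nM, and compound 3 `COc1cccc(C(c2c[nH]c3ccc(Br)cc23)c2c[nH]c3ccc(Br)cc23)c1OC` gives 89000 nM.

Compound 4 `COc1ccc(C(c2c[nH]c3ccc(Br)cc23)c2c[nH]c3ccc(Br)cc23)c(OC)c1` has not yet been measured. Its difference from compound 2 is 2,4-dimethoxyphenyl in place of 3-hydroxyphenyl on a saturated chain carbon bound to two aromatic carbons.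

Among the measured compounds shown here, the one measured step that bears on this is a 32-fold higher number from compound 2 to compound 3 (1.50 log units; beyond the scatter), with 2,3-dimethoxyphenyl in place of 3-hydroxyphenyl at the same place. For the measured compounds named here, compound 1 differs from compound 2 in more than one place and gives no clean step. Going by the values given here, no measured compound carries the 2,4-dimethoxyphenyl group, so the transfer rests on a single pair. A large step towards a higher number is therefore expected in this assay. The estimated step is a 21-fold higher number from compound 2 to compound 4 (1.33 log units; beyond the scatter). For compound 4 the expected value is 60000 nM, with an estimated range of 20000 nM to 180000 nM.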

Compound 4, half-maximal inhibitory concentration: 77500 nM
Estimate against measurement, compound 4: 1.3-fold (0.11 log units) below; the measured number falls inside the stated range.
By their numbers in this assay, from the lowest: compound 2; then compound 1; then compounds 4 and 3 (each within the scatter of the next).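

In this assay, a second dimethoxyphenyl group on the saturated chain carbon bound to two aromatic carbons gives a 28-fold higher number from compound 2 to compound 4 (1.44 log units; beyond the scatter), so the large step is no longer tied to the 2,3-dimethoxyphenyl group alone. The two dimethoxyphenyl groups do not separate, with a 1.1-fold lower number from compound 3 to compound 4 (0.06 log units; within the scatter), and this change of substitution pattern has no readable effect in this pair. Nothing measured here offers a reason for the large steps away from the 3-hydroxyphenyl group.

The hydroxyl group leaves and two methoxy groups enter in the same change, so the shown compounds cannot say which of these carries the step. Also open, from the compounds shown here alone, is how a single methoxy group, an amine or a carboxylic acid on the phenyl ring would read at this place.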